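This account rests on a few compounds, and the source may have more. Where it says the series, first, only, none or still open, it means among the compounds named here.

Compound 1 `Cc1ccc(S(=O)(=O)N/C(=N\O)Nc2ccc(Cl)cc2)cc1` gives 58 ug/mL
Compound 2 `N#Cc1c(Cl)cccc1Oc1ccc(S(=O)(=O)N/C(=N\O)Nc2ccc(Cl)cc2)cc1` gives 178 ug/mL
Compound 3 `CCCCOc1ccc(S(=O)(=O)N/C(=N\O)Nc2ccc(Cl)cc2)cc1` is not yet measured

Among the measured compounds shown here, in a functional assay on COLO 205 cells (Homo sapiens) for cytotoxicity (a higher number here means a weaker inhibitor, a lower number a stronger inhibitor), compound 2 at 178 ug/mL is the higher of the two numbers and so the weaker inhibitor of the pair, with compound 1 at 58 ug/mL as its only neighbour. The next change is butyl in place of 3-chloro-2-cyanophenyl on an oxygen on an aromatic ring in words: butyl in place of 3-chloro-2-cyanophenyl on an oxygen on an aromatic ring, or 3-chloro-2-cyanophenoxy to butoxy.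

For the measured compounds named here, only one measured step bears on this: a 3.1-fold higher number from compound 1 to compound 2 (0.49 log units; beyond the scatter) when 3-chloro-2-cyanophenoxy replaces methyl on an aromatic carbon. That step is modest but beyond the scatter. Going by the values given here, compound 3 loses the same 3-chloro-2-cyanophenoxy group, though butoxy is not the methyl of compound 1, and no alkoxy compound has been measured. A partial return towards compound 1 in this assay is therefore expected, with a modest fall and real uncertainty about its size. The estimated change is a 1.9-fold lower number from compound 2 to compound 3 (0.27 log units; within the scatter) on this reading. For compound 3 the expected value is 95 ug/mL within an estimated range of 40 ug/mL to 200 ug/mL for now.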

Compound 3, half-maximal inhibitory concentration: 49 ug/mL
Compound 3: the middle estimate sits 1.9-fold (0.29 log units) above what was measured, and the stated range covers the measured number.
By their numbers in this assay, from the lowest: compounds 3 and 1 (each within the scatter of the next); then compound 2.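

In this assay, butyl in place of 3-chloro-2-cyanophenyl on the oxygen gives a 3.6-fold lower number from compound 2 to compound 3 (0.56 log units; beyond the scatter), so the ether oxygen kept in compound 3 does not by itself carry the higher number of compound 2; that number goes with the 3-chloro-2-cyanophenyl group. Butoxy in place of methyl gives a 1.2-fold lower number from compound 1 to compound 3 (0.07 log units; within the scatter), which shows that in this assay the position takes a butyl chain on oxygen with no readable difference from methyl, and compound 1 and compound 3 cannot be placed in any order. No measurement on hand bears on what lies behind either step.

The compounds shown leave open whether a plain phenoxy group would behave like 3-chloro-2-cyanophenoxy or like butoxy, and so whether the aromatic ring, the chlorine or the nitrile goes with the higher number of compound 2. They also leave open whether the flat response between methyl and butoxy holds for a longer chain such as octyloxy, or for a group of a different kind here, such as an amine or a carboxylic acid.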